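Swapping the sulfur-linked ring of compound 3

This account rests on a few compounds, and the source may have more. Where it says the series, first, only, none or still open, it means among the compounds named here.

In a functional assay on NCI-H1975 cells (Homo sapiens) for inhibition, read by MTT assay, with a stated time of 72 h (on this read-out lower numbers stand for stronger inhibition and higher numbers for weaker inhibition), compound 3 `Cc1csc(Sc2cc(C(F)(F)F)nc(SCc3ccc(C(F)(F)F)cc3)n2)n1` gives 5840 nM, the lower of the two actual numbers, while compound 1 `CCN1CCN(c2cc(C(F)(F)F)nc(SCc3ccc(C(F)(F)F)cc3)n2)CC1` gives 15000 nM. Compound 2 `CC(C)(C)OC(=O)N1CCN(c2cc(C(F)(F)F)nc(SCc3ccc(C(F)(F)F)cc3)n2)CC1` reads > 50000 nM, which is a limit of the assay and not a number. Compound 4 `FC(F)(F)c1ccc(CSc2nc(Sc3ccccn3)cc(C(F)(F)F)n2)cc1` keeps the shared core and differs at one place: pyridin-2-yl in place of 4-methyl-1,3-thiazol-2-yl on a sulfur. Within the data shown here, the only measured step reaching this position is a 2.6-fold lower number from compound 1 to compound 3 (0.41 log units; beyond the scatter), and it replaced 4-ethylpiperazin-1-yl, so it says little about exchanging one ring on sulfur for another. The other step, an at least 3.3-fold higher number from compound 1 to compound 2 (0.52 log units; beyond the scatter), lies elsewhere and does not bear on this change. The expected change is a 1.2-fold higher number from compound 3 to compound 4 (0.08 log units; within the scatter), with no step beyond the scatter expected in this assay. Compound 4 is estimated at 7000 nM, with an expected range of 2800 nM to 18000 nM.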

Compound 4, half-maximal inhibitory concentration: 23900 nM
Compound 4: the middle estimate sits 3.4-fold (0.53 log units) below what was measured, and the stated range ends below it.
By their numbers in this assay, from the lowest: compound 3; then compounds 1 and 4 (each within the scatter of the next). At a limit, above all of these: compound 2.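

The ring on sulfur matters at this position: in this assay, pyridin-2-yl in place of 4-methyl-1,3-thiazol-2-yl gives a 4.1-fold higher number from compound 3 to compound 4 (0.61 log units; beyond the scatter). Against 4-ethylpiperazin-1-yl, (pyridin-2-yl)sulfanyl gives a 1.6-fold higher number from compound 1 to compound 4 (0.20 log units; within the scatter), so the advantage of (4-methyl-1,3-thiazol-2-yl)sulfanyl does not extend to this other aromatic ring on sulfur. Nothing measured here accounts for the step.

Still open, on these data alone, is whether the methyl group or the five-membered ring carries the difference. Also open, as far as these compounds go, is how a 1,3-thiazol-2-yl without methyl, or a phenyl, would read on the same sulfur.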